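Swapping a Ring Amine for Dimethylamino in Cell Toxicity

The source may hold more compounds than are shown below. What is called first, only, known or untested is meant among the compounds shown, and "the series" means these compounds.

Of the compounds shown here, three have been measured in an ADME assay on L6 cells (Rattus norvegicus) for cytotoxicity; a higher number here means a weaker inhibitor, a lower number a stronger inhibitor. Compound 1 `CN1CCN(CCN2CCC3(N(C)C)CC(c4ccccc4)C2C(c2ccccc2)C3)CC1` gives 70300 nM, compound 2 `CN1CCN(CCN2CCC3(N4CCCC4)CC(c4ccccc4)C2C(c2ccccc2)C3)CC1` gives 50300 nM, and compound 3 `CN1CCN(CCCC(=O)OC2CC3(N4CCCC4)CC(c4ccccc4)C2C(c2ccccc2)C3)CC1` gives 10200 nM. How the core of compound 3 differs from the core of compound 2 is not broken down here. Between compound 2 and compound 1 a single change is made: dimethylamino in place of pyrrolidin-1-yl on a saturated ring carbon. In this assay that change produced a 1.4-fold higher number from compound 2 to compound 1 (0.15 log units; within the scatter).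

Compound 4 `CN1CCN(CCCC(=O)OC2CC3(N(C)C)CC(c4ccccc4)C2C(c2ccccc2)C3)CC1` has not yet been measured. It differs from compound 3 by the same kind of change: dimethylamino in place of pyrrolidin-1-yl on a saturated ring carbon. The surroundings are not identical: in compound 2 there are two ring bonds from two ring atoms that each bear a phenyl group, whereas in compound 3 there are two ring bonds from the ring atom that bears a large group and two ring bonds from the ring atom that bears a phenyl group.

In this assay the step expected is a 1.4-fold higher number from compound 3 to compound 4 (0.14 log units; within the scatter), because the same change earlier gave a 1.4-fold higher number from compound 2 to compound 1 (0.15 log units; within the scatter). Compound 4 is therefore estimated at 14000 nM, expected to fall between 6000 nM and 32000 nM.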

Compound 4, half-maximal inhibitory concentration: 19900 nM
For compound 4 the middle estimate is 1.4-fold (0.15 log units) below the measured one; measured number inside the range.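

Placing dimethylamino where pyrrolidin-1-yl stood on the core of compound 3 gives a 2.0-fold higher number from compound 3 to compound 4 (0.29 log units; within the scatter) in this assay. Set beside the earlier step, this shows that the change carries across the two cores without a difference that can be told from the scatter: the same change on two cores in this assay, a 1.4-fold higher number (0.15 log units; within the scatter) from compound 2 to compound 1 and a 2.0-fold higher number (0.29 log units; within the scatter) from compound 3 to compound 4, 1.4-fold (0.14 log units) apart, within the scatter of two such steps. On each core the step itself also stays within the scatter, so these two pairs show no clear effect of the swap, but two cores cannot show that it would behave the same way on a third, and they do not explain why the numbers fall as they do.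

The compounds shown leave open whether other amines on that saturated ring carbon, such as piperidin-1-yl, morpholin-4-yl or a plain amino group, would also stay within the scatter of these two. They also leave open whether a ring amine larger than pyrrolidin-1-yl would give a step beyond the scatter on either core.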